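Notes on methoxy removal in a selenium-ring cytotoxicity series

This account rests on a few compounds, and the source may have more. Where it says the series, first, only, none or still open, it means among the compounds named here.

In an ADME assay on Detroit 551 cells (Homo sapiens) for cytotoxicity, read by MTT assay, with a stated time of 48 h (on this read-out lower numbers stand for stronger inhibition and higher numbers for weaker inhibition), compound 1 `COc1ccc2[nH]c(-c3ccc[se]3)cc(=O)c2c1` gives > 10000 nM, a limit of the assay.
In this assay compound 2 `COc1ccc2[nH]c(-c3ccc(C)[se]3)cc(=O)c2c1OC` gives > 50000 nM, also a limit.
In this assay compound 3 `COc1ccc2[nH]c(-c3cc[se]c3)cc(=O)c2c1OC` gives > 100000 nM, again a limit.

Compound 3 therefore stands at the limit of > 100000 nM in this assay, at which 1 of the 3 values shown sits. Compound 1 stands at the limit of > 10000 nM in this assay, at which 1 of the 3 values shown sits. Compound 2 stands at the limit of > 50000 nM in this assay, at which 1 of the 3 values shown sits. With every value a limit, no ordering among the three is possible. For the measured compounds named here, the only single-point step measured, a step that the two limits leave unreadable from compound 2 to compound 3, gives no readable size.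

Compound 4 `COc1ccc2[nH]c(-c3cc[se]c3)cc(=O)c2c1` differs from compound 3 by hydrogen in place of methoxy on an aromatic carbon. Going by the values given here, no measured step covers this change, so the expectation rests on the limits alone. The expected value for compound 4 in this assay is 100000 nM, within 20000 nM to 300000 nM. The expected step for compound 4 is a number no higher from compound 3 to compound 4 (the limit leaves the size open), most likely reported as a limit again.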

Compound 4, half-maximal inhibitory concentration: > 10000 nM
Compound 4 ended at the assay's limit; the forecaster's own chance of this, stated with the estimate: 80%; the middle value lies beyond the limit too.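

Neither step to compound 4, from compound 3 or from compound 1, can be read, since all these values in this assay are limits. The compounds shown leave open how far hydrogen in place of methoxy changes cytotoxicity, if at all.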